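A Hydroxy and Methoxy Swap Without a Baseline

A few compounds are considered here, and "the series" means these few. Any claim that something is new, unique, unknown or untested is made for them only; others in the source may bear on it.

Compound 1 `COc1ccc(/C=C/C(=O)c2ccc(N)c(-c3ccc(F)cc3)c2)cc1O`: "not determined" (no result reported)
Compound 2 `COc1ccc(/C=C/C(=O)c2ccc(NC(C)=O)c(-c3ccc(F)cc3)c2)cc1OC`: 5630 nM

In a functional assay on HepG2 cells (Homo sapiens) for cytotoxicity, read by sulforhodamine B assay, with a stated time of 48 h (on this read-out lower numbers stand for stronger inhibition and higher numbers for weaker inhibition), compound 1 has the entry "not determined" (no result reported), so it stands without a single number and offers no baseline for comparison. The only figure available in this small set belongs to compound 2, at 5630 nM. Compound 3 `COc1cc(/C=C/C(=O)c2ccc(N)c(-c3ccc(F)cc3)c2)ccc1O` has the same atoms as compound 1, joined differently: 4-hydroxy-3-methoxyphenyl in place of 3-hydroxy-4-methoxyphenyl on a double-bonded chain carbon bound to a double-bonded chain carbon. The exchange takes place on a double-bonded chain carbon bound to a double-bonded chain carbon, and the rest of the structure stays the same. No measured step exists to guide the expectation, and the data give no reason to favour either direction. The step from the one structure to the other is therefore expected to stay within the usual scatter in this assay, although the missing result for compound 1 means this cannot be checked directly. Among the compounds with values here, the expected level instead rests on the single value of compound 2, 5630 nM, which is a weak anchor and calls for a wide range. The estimate for compound 3 is 6000 nM, with an expected range from 2000 nM to 20000 nM.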

Compound 3, half-maximal inhibitory concentration: 4300 nM
Beside the measured number, compound 3's estimate is 1.4-fold (0.14 log units) above it, within the range that was stated.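

In this assay, within the data shown here, compound 3 gives 4300 nM, but compound 1 has no single number, so no step between compound 1 and compound 3 can be read. The compounds shown leave open whether exchanging 3-hydroxy-4-methoxyphenyl for 4-hydroxy-3-methoxyphenyl alters the read-out at all. No available evidence bears on this result.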